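This account rests on a few compounds, and the source may have more. Where it says the series, first, only, none or still open, it means among the compounds named here.

Measured compounds:
- compound 1, `Cc1ccc2ncc(S(=O)(=O)c3ccc(F)cc3)c(N3CCC(C)CC3)c2c1`: 90%
- compound 2, `CC1CCN(c2c(S(=O)(=O)c3ccc(F)cc3)cnc3cc(F)ccc23)CC1`: 74.5%
- compound 3, `Cc1ccc2ncc(S(=O)(=O)c3ccc(Cl)cc3)c(N3CCC(C)CC3)c2c1`: 79%

All three were tested in an assay on isolated protein for displacement of a labelled ligand from metabotropic glutamate receptor 5 (Homo sapiens), with a stated time of 60 min, tested at 1 uM; on this read-out higher numbers stand for more inhibition at the one concentration tested (going by the name of the read-out) and lower numbers for less inhibition. In this assay compound 1 gives 90%, compound 3 gives 79% and compound 2 gives 74.5%. Compound 1 and compound 3 share one core and differ in a single spot: chloro in place of fluoro on an aromatic carbon. That change produced a number 11 percentage points lower from compound 1 to compound 3 (beyond the scatter). Compound 2 is built on a different core; how its core differs from that of compound 1 is not broken down here. Compound 2 and compound 3 lie within the usual scatter of each other, so nothing can be said about which of the two is higher.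

For the measured compounds named here, the unmeasured compound 4, `CC1CCN(c2c(S(=O)(=O)c3ccc(F)cc3)cnc3cc(Cl)ccc23)CC1`, is derived from compound 2 by the same kind of change as the one from compound 1 to compound 3: chloro in place of fluoro on an aromatic carbon. It is the same kind of change but not the same one, since it sits at a different place: in compound 3 the new chloro stands on a six-membered aromatic ring of carbon only, para to a large group, whereas in compound 4 it stands on a ring that is part of a fused or bridged system of two rings, meta to a fused ring and para to a fused ring. Going by the values given here, with only the single earlier step as a guide, and at a different place, the expectation for compound 4 is a drop of similar size, with wide margins; compound 4 is expected to give 66%, between 45% and 82%, which means an expected step of a number 8.5 percentage points lower from compound 2 to compound 4 (within the scatter).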

Compound 4, a percentage reported as inhibition, at one concentration (the size of the read-out at that concentration, not a potency): 91%
For compound 4 the middle estimate is 25 percentage points below the measured one; measured number above the stated range.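

In this assay, putting chloro in place of fluoro on an aromatic carbon of the core of compound 2 gave a number 16.5 percentage points higher from compound 2 to compound 4 (beyond the scatter), so here the exchange raises the number rather than lowering it. Set beside the earlier step, this shows that the effect of this exchange did not carry over from one core to the other, even in its direction: the same change on two cores in this assay, a number 11 percentage points lower (beyond the scatter) from compound 1 to compound 3 and a number 16.5 percentage points higher (beyond the scatter) from compound 2 to compound 4, 27.5 percentage points apart, beyond the scatter of two such steps What this does not show is the reason for the difference, since the two steps differ both in the core and in the place of the new chloro, and two steps cannot separate these. The read-out also comes from one concentration, so the steps describe inhibition at that concentration and say nothing direct about potency.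

The compounds shown leave open how a bromo, a methoxy group or a nitrile would compare with fluoro and chloro at the place the chloro occupies in compound 4. They also leave open whether the exchange would raise or lower the number on a third core, or with the chloro placed elsewhere on the core of compound 2.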